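A few compounds are considered here, and "the series" means these few. Any claim that something is new, unique, unknown or untested is made for them only; others in the source may bear on it.

Three compounds have been measured in a functional assay on KB cells (Homo sapiens) for cytotoxicity, read by sulforhodamine B assay; a lower number here means a stronger inhibitor, a higher number a weaker inhibitor:
Compound 1 `C=C1[C@@H](OC(C)=O)C[C@@H]2[C@](C)(COC=O)[C@H](OC(C)=O)CC[C@@]2(C)[C@@H]1C[C@@H](Nc1ccc(OC)c(OC)c1)C1=CCOC1=O` gives a limit of the assay, > 50000 nM, and no number.
Compound 2 `C=C1[C@@H](OC(C)=O)C[C@@H]2[C@](C)(COC=O)[C@H](OC(C)=O)CC[C@@]2(C)[C@@H]1C[C@@H](Nc1ccc(O)cc1)C1=CCOC1=O` gives 28900 nM.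
Compound 3 `C=C1[C@@H](OC(C)=O)C[C@@H]2[C@](C)(COC=O)[C@H](OC(C)=O)CC[C@@]2(C)[C@@H]1C[C@@H](Nc1ccc(OC)cc1)C1=CCOC1=O` gives 32700 nM.

Compound 3 gives the higher of the two numbers, with compound 2 nearest at a 1.1-fold higher number from compound 2 to compound 3 (0.05 log units; within the scatter), and the third value is a limit (the limit of > 50000 nM in this assay, at which 1 of the 3 values shown sits). Compound 4 `C=C1[C@@H](OC(C)=O)C[C@@H]2[C@](C)(COC=O)[C@H](OC(C)=O)CC[C@@]2(C)[C@@H]1C[C@@H](Nc1cccc(F)c1)C1=CCOC1=O` differs from compound 3 by 3-fluorophenyl in place of 4-methoxyphenyl on an amine nitrogen. Among the compounds with values here, no measured step exchanges methoxy for fluorine; the two steps that touch the aryl group, an at least 1.7-fold lower number from compound 1 to compound 2 (0.23 log units; that floor lies within the scatter) and an at least 1.5-fold lower number from compound 1 to compound 3 (0.18 log units; that floor lies within the scatter), start from a limit and give only floors within the scatter, and a 1.1-fold higher number from compound 2 to compound 3 (0.05 log units; within the scatter) also lies within the scatter. Compound 4 is therefore expected to show no step beyond the scatter in this assay, a 1.0-fold lower number from compound 3 to compound 4 (0.01 log units; within the scatter), and its estimated value is 32000 nM with a range of 12000 nM to 80000 nM.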

Compound 4, half-maximal inhibitory concentration: 28600 nM
For compound 4 the middle estimate is 1.1-fold (0.05 log units) above the measured one; the measured number falls inside the stated range.
By their numbers in this assay, from the lowest: compounds 4, 2 and 3 (each within the scatter of the next). At a limit, above all of these: compound 1.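

In this assay, 3-fluorophenyl on the amine nitrogen brings a ring with no oxygen, yet the number does not move beyond the scatter from those of the oxygen-bearing rings: a 1.1-fold lower number from compound 3 to compound 4 (0.06 log units; within the scatter) and a 1.0-fold lower number from compound 2 to compound 4 (0.00 log units; within the scatter). The step of an at least 1.7-fold lower number from compound 1 to compound 4 (0.24 log units; that floor lies within the scatter) starts from a limit, so it gives only a floor. Compound 1 gives a limit and no number: the limit of > 50000 nM in this assay, at which 1 of the 4 values shown sits.

The compounds shown leave open whether a carboxylic acid or an amine on the aryl ring, or a longer chain in place of the ring on this nitrogen, would give a step beyond the scatter.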